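The source may report more compounds than this note shows. Statements on the series, on what has been measured and on what is new or still open speak of the compounds shown alone.

Of the compounds shown here, three built on a shared core have been measured in an assay for inhibition of serine/threonine-protein kinase Sgk1 (Homo sapiens), with stated times of 30 min and 60 min, in the presence of a further agent that is not named here; a higher number here means a weaker inhibitor, a lower number a stronger inhibitor. Compound 1 `CC(C)N1CC[C@H](NC(=O)c2cc(-c3ccc(NS(=O)(=O)c4cccc(Cl)c4Cl)cc3)nc3[nH]ncc23)C1` gives 38 nM. Compound 2 `O=C(NC1CCN(C2CC2)C1)c1cc(-c2ccc(NS(=O)(=O)c3cccc(Cl)c3Cl)cc2)nc2[nH]ncc12` gives 610 nM, and compound 3 `NC(=O)c1cc(-c2ccc(NS(=O)(=O)c3cccc(Cl)c3Cl)cc2)nc2[nH]ncc12` gives 236 nM. Compound 3 therefore holds the second highest of the three numbers, with a 6.2-fold higher number from compound 1 to compound 3 (0.79 log units; beyond the scatter) and a 2.6-fold lower number from compound 2 to compound 3 (0.41 log units; beyond the scatter); the two pyrrolidinyl compounds themselves are separated by a 16-fold higher number from compound 1 to compound 2 (1.21 log units; beyond the scatter).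

Compound 4 `CCNC(=O)c1cc(-c2ccc(NS(=O)(=O)c3cccc(Cl)c3Cl)cc2)nc2[nH]ncc12` differs from compound 3 by ethyl in place of hydrogen on an amide-type nitrogen. The measured steps that bear on this position both replaced the hydrogen with a substituted pyrrolidinyl group, and they point in opposite directions: a large gain with the isopropyl-bearing ring, a modest loss with the cyclopropyl-bearing ring. Within the data shown here, no measured step puts a plain chain on this nitrogen, so the swing seen between the two ring substituents gives no clear direction for an ethyl group. Compound 4 is therefore expected to show a 1.2-fold lower number from compound 3 to compound 4 (0.07 log units; within the scatter), a change that may not exceed the scatter. On that basis compound 4 is estimated at 200 nM in this assay, with a range from 60 nM to 650 nM.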

Compound 4, half-maximal inhibitory concentration: < 1920 nM
Compound 4: no number, only a limit; the forecaster's own chance of this, stated with the estimate: 3%; the middle value is on the limit's open side.
By their numbers in this assay, from the lowest: compound 1; then compound 3; then compound 2.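

In this assay compound 4 gives < 1920 nM, which is a limit and not a number. Among these compounds, no step from compound 1, compound 2 or compound 3 to compound 4 can therefore be read. The compounds shown leave open whether ethyl in place of hydrogen on the amide-type nitrogen changes the number seen for compound 3, and in which direction.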